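Series notes: chain substituent exchange at compound 1

The source may report more compounds than this note shows. Statements on the series, on what has been measured and on what is new or still open speak of the compounds shown alone.

Measured compounds:
- compound 1 `OC(CCCN1CCN(c2ncc(F)cn2)CC1)C1CCCCC1`: 12 nM in an assay (Cavia porcellus) for displacement of a labelled ligand from Sigma non-opioid intracellular receptor 1 (Homo sapiens); a higher number here means a weaker inhibitor, a lower number a stronger inhibitor
- compound 3 `O=C(OC(CCCN1CCN(c2ncc(F)cn2)CC1)c1ccc(F)cc1)c1ccccc1`: 3500 nM in this assay
- compound 2 `OC(CCCN1CCN(c2ncc(F)cn2)CC1)(c1ccc(F)cc1)C1CCCCC1`: no result reported in this assay

Compound 1 holds the lower of the two numbers available in this assay. The nearest measured neighbour, compound 3, lies far above it, beyond the usual scatter. Compound 2 has no number, so it adds nothing to the ordering. Compounds 1 and 3 differ in more than one place, so their gap cannot be read as the effect of any single change.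

Compound 4 `Fc1ccc(OCCCN2CCN(c3ncc(F)cn3)CC2)cc1` is the next entry for this assay. It differs from compound 1 as follows: 4-fluorophenoxy in place of cyclohexyl(hydroxy)methyl on a saturated chain carbon, three bonds along the chain from an amine nitrogen in a ring. Among the measured compounds shown here, no measured pair isolates this exchange, so there is no step to lean on. The shared core and the chain length are kept, and one ring substituent of the same heavy-atom count replaces another. The working expectation is a step of at most moderate size, with some lean towards a higher number, and a result within the scatter of compound 1 remains plausible.

For compound 4 the estimate in this assay is 25 nM, with a range from 4 nM to 150 nM. The step this estimate implies is a 2.1-fold higher number from compound 1 to compound 4 (0.32 log units; beyond the scatter), expected rather than measured.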

Compound 4, half-maximal inhibitory concentration: 89 nM
Estimate against measurement, compound 4: 3.6-fold (0.55 log units) below, and the stated range covers the measured number.
By their numbers in this assay, from the lowest: compound 1; then compound 4; then compound 3.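

In this assay, among the compounds shown here, this exchange on a saturated chain carbon, three bonds along the chain from an amine nitrogen in a ring, gives the first step that can be read as a single change: a 7.4-fold higher number from compound 1 to compound 4 (0.87 log units; beyond the scatter) is beyond the scatter, so the two groups are not interchangeable here, even at equal heavy-atom count. The loss is partial, since compound 4 still gives 89 nM without the hydrogen-bond donor of cyclohexyl(hydroxy)methyl and with an aromatic ring in place of a non-aromatic one, which shows that neither that donor nor a non-aromatic ring is needed for a measurable number at this position. No measurement shown here bears on why the number rises.

The exchange alters the ring type, the donor count and the fluorine together, so the step cannot be divided among them. On these data alone, it remains open whether a cyclohexyloxy group or an unsubstituted phenoxy group at this chain carbon would stand closer to compound 1 or to compound 4.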